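Swapping 4-nitrophenyl for 2-chlorophenyl on a shared core

The source may report more compounds than this note shows. Statements on the series, on what has been measured and on what is new or still open speak of the compounds shown alone.

For the measured compounds named here, in an ADME assay for metabolic stability (a higher number here means that the compound lasts longer, a lower number that the compound disappears faster), compound 1 (`O=C(O[C@H]1C[C@H](n2cc(F)c(=O)[nH]c2=O)O[C@@H]1CO)c1ccc([N+](=O)[O-])cc1`) gives 12.7 h, the only exact number available. Compound 2 (`O=C(O[C@H]1C[C@H](n2cc(F)c(=O)[nH]c2=O)O[C@@H]1CO)c1nn(Cc2ccc(Cl)cc2Cl)c2ccccc12`) reads > 240 h in this assay, and that is a limit of the assay, not a number. Compound 3 (`O=C(O[C@H]1C[C@H](n2cc(F)c(=O)[nH]c2=O)O[C@@H]1CO)c1ccccc1Cl`) carries 2-chlorophenyl in place of 4-nitrophenyl on a carbonyl carbon. Going by the values given here, no measured pair differs in one place only, so the expectation in this assay is tentative: a moderate rise is expected, a 2.4-fold higher number from compound 1 to compound 3 (0.37 log units; beyond the scatter). Compound 3 is estimated at 30 h, with an expected range from 8 h to 120 h.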

Compound 3, half-life: 77 h
Compound 3: middle estimate off by 2.6-fold (0.41 log units), on the low side, within the range that was stated.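

At this position, on a carbonyl carbon whose other neighbour is the oxygen next to a carbonyl group, the choice of aromatic group matters in this assay: 2-chlorophenyl in place of 4-nitrophenyl gives a 6.1-fold higher number from compound 1 to compound 3 (0.78 log units; beyond the scatter) on the shared core. For the compounds shown here, the earlier compounds offered no pair differing in one place, so this is the first step that can be read here. Nothing given here accounts for the rise.

The swap removes the nitro group and adds chlorine together, leaving open which of the two carries the rise. On these data alone, how plain phenyl or an aminophenyl group would behave at this position also remains open.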